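This account rests on a few compounds, and the source may have more. Where it says the series, first, only, none or still open, it means among the compounds named here.

The account follows one change made to compound 1 `COc1ccc(-c2cnc(NC(=O)c3ccccc3F)n2C)cc1` and asks what it does to tolerance in a toxicity assay on THP-1 cells (Homo sapiens) for inhibition; a higher number here means that more compound is tolerated, a lower number that less compound is tolerated. Compound 1 itself returns no number: in this assay compound 1 gives > 100000 nM, which is a limit of the assay. Two further compounds share this picture. Compound 2 `COc1ccc(CNC(=O)NC(=O)c2ccc(F)cc2)cc1` gives > 50000 nM in this assay, a limit. Compound 3 `Cn1c(-c2cccc(C#N)c2)cnc1NC(=O)c1ncc[nH]1` gives > 50000 nM in this assay, again a limit. Compound 1 thus stands at the limit of > 100000 nM in this assay, at which 1 of the 3 values shown sits, while the other two values sit at the limit of > 50000 nM in this assay, at which 2 of the 3 values shown sit; none of the three is a measured number, and none shows toxicity within the tested range.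

Compound 4 `COc1ccc(-c2cnc(NC(=O)c3ccn[nH]3)n2C)cc1` is derived from compound 1 by a single change: 1H-pyrazol-5-yl in place of 2-fluorophenyl on a carbonyl carbon. For the measured compounds named here, no measured step between compounds exists here, and all three compounds sit at limits. The step of a number no higher from compound 1 to compound 4 (the limit leaves the size open) is therefore expected to be none beyond the scatter. Compound 4 is expected to give 100000 nM in this assay, in a range from 50000 nM to 300000 nM, and most probably to be reported once more only as a limit rather than as a number.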

Compound 4, half-maximal cytotoxic concentration: > 100000 nM
Compound 4 ended at the assay's limit (the forecaster's own chance of this, stated with the estimate: 80%); the middle value sits exactly at the limit.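

In this assay compound 4, like compound 1, is reported only as a limit, so no step can be read between the two. The compounds shown leave open how much of either compound the cells would tolerate, and whether 1H-pyrazol-5-yl in place of 2-fluorophenyl on a carbonyl carbon changes that tolerance at all.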